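Furan in place of methylsulfonylphenyl on the amine side chain

This account rests on a few compounds, and the source may have more. Where it says the series, first, only, none or still open, it means among the compounds named here.

Measured so far:
compound 1, `O=S(=O)(NCC1CCN(CCCc2c[nH]c3ccc(-n4cnnc4)cc23)CC1)c1ccccc1`: 60 nM
compound 2, `CN(Cc1ccc(S(C)(=O)=O)cc1)C1CCN(CCCc2c[nH]c3ccc(-n4cnnc4)cc23)CC1`: 140 nM

Both compounds were tested in an assay on CHO cells for displacement of a labelled ligand from 5-hydroxytryptamine receptor 1B (Homo sapiens); on this read-out lower numbers stand for stronger inhibition and higher numbers for weaker inhibition. Of the two numbers, compound 2 gives the highest, at 140 nM, while compound 1 gives 60 nM, a difference that lies beyond the usual scatter of repeated measurements.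

Compound 3, `CN(Cc1ccco1)C1CCN(CCCc2c[nH]c3ccc(-n4cnnc4)cc23)CC1`, is not yet measured. It keeps the whole of compound 2 except one part: furan-2-yl in place of 4-(methylsulfonyl)phenyl on a saturated chain carbon bound to an amine nitrogen. The methylsulfonyl group and its six-membered ring are gone, and a five-membered ring with one oxygen stands in their place on the same chain carbon bound to the amine nitrogen.

For the measured compounds named here, no measured pair in this set shows exactly this change, so there is no step to lean on. The expectation is therefore a step from compound 2 to compound 3 of a 1.1-fold lower number from compound 2 to compound 3 (0.03 log units; within the scatter), that is, one that may well stay within the scatter in either direction. Compound 3 is estimated at 130 nM, with a range from 45 nM to 400 nM.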

Compound 3, half-maximal inhibitory concentration: 89 nM
The estimate for compound 3 lay 1.5-fold (0.16 log units) above the measured number, within the range that was stated.
By their numbers in this assay, from the lowest: compounds 1, 3 and 2 (each within the scatter of the next, the first and the last beyond it).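

In this assay, furan-2-yl in place of 4-(methylsulfonyl)phenyl on a saturated chain carbon bound to an amine nitrogen gives a 1.6-fold lower number from compound 2 to compound 3 (0.20 log units; within the scatter), so in this one pair the methylsulfonyl group and its six-membered ring can go without a shift that stands out from the scatter. The other new step, a 1.5-fold higher number from compound 1 to compound 3 (0.17 log units; within the scatter), also lies within the scatter, so compound 3 cannot be told apart from either compound 1 or compound 2, even though those two differ from each other by more than the scatter. No accompanying data explain why the numbers fall where they do.

For the compounds shown here, with only two groups compared on this chain carbon, the pair cannot show which part of 4-(methylsulfonyl)phenyl matters, if any, since plain phenyl would separate the effect of the ring from that of the methylsulfonyl group. From the compounds shown here alone, it also remains open whether an aromatic ring is needed here at all, a question that thiophene-2-yl and cyclohexyl on the same carbon could begin to answer.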